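The source may report more compounds than this note shows. Statements on the series, on what has been measured and on what is new or still open speak of the compounds shown alone.

Measured compounds and their values:
Compound 1 `Fc1ccc([C@@H]2C[C@@H]3Cc4ccc5ccccc5c4N2O3)cc1` gives > 300000 nM.
Compound 2 `Clc1cccc([C@@H]2C[C@@H]3Cc4ccc5ccccc5c4N2O3)c1` gives > 300000 nM.
Compound 3 `Cc1cccc([C@@H]2C[C@@H]3Cc4ccc5ccccc5c4N2O3)c1` gives > 300000 nM.

The series is read in an ADME assay on THP-1 cells (Homo sapiens) for cytotoxicity, read by MTT assay, with a stated time of 72 h; a higher number here means that more compound is tolerated, a lower number that less compound is tolerated. Compound 1 stands at > 300000 nM, which is a limit of the assay and not a number. The value of compound 2, > 300000 nM, is likewise a limit. The value of compound 3, > 300000 nM, is a limit as well. All three values therefore sit at the limit of > 300000 nM in this assay, at which 3 of the 3 values shown sit, and none of the steps among them can be read: a step that the two limits leave unreadable from compound 1 to compound 2, a step that the two limits leave unreadable from compound 1 to compound 3 and a step that the two limits leave unreadable from compound 2 to compound 3.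

Compound 4 `Clc1ccc([C@@H]2C[C@@H]3Cc4ccc5ccccc5c4N2O3)c(Cl)c1` is not yet measured. It differs from compound 1 thus: 2,4-dichlorophenyl in place of 4-fluorophenyl on a saturated ring carbon. Going by the values given here, the measured steps that bear on it are the aryl swaps from compound 1 to compound 2 and to compound 3, both of which are unreadable between limits; no step to an aryl ring carrying two chlorines has been measured. Nothing among the shown values suggests a step beyond the scatter in this assay in either direction, and the expected step from compound 1 to compound 4 is a number no higher from compound 1 to compound 4 (the limit leaves the size open). Compound 4 is thus expected to give about 300000 nM in this assay, with a range of 150000 nM to 600000 nM, most probably reported again only as a limit.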

Compound 4, half-maximal cytotoxic concentration: > 250000 nM
Compound 4 gave a limit, no number (the forecaster's own chance of this, stated with the estimate: 80%); the middle value does not contradict the limit.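

In this assay compound 4 gives > 250000 nM, which is a limit and not a number. Going by these compounds alone, with compound 1, compound 2 and compound 3 also standing at limits, no step to compound 4 can be read. Open, on these data alone, is the concentration, if any, at which these four compounds turn cytotoxic, and whether the aryl swaps shift it.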